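A few compounds are considered here, and "the series" means these few. Any claim that something is new, unique, unknown or untested is made for them only; others in the source may bear on it.

Measured in a functional assay on A549 cells (Homo sapiens) for antiproliferative activity, read by MTT assay, with a stated time of 72 h; a higher number here means a weaker inhibitor, a lower number a stronger inhibitor:
- Compound 1 `O=C(N/N=C/c1cccc(Br)c1)Nc1ccc(Oc2ccnc3[nH]ccc23)c(F)c1`: 2220 nM
- Compound 2 `O=C(N/N=C/c1ccc(Cl)c(Cl)c1)Nc1ccc(Oc2ccnc3[nH]ccc23)c(F)c1`: 2650 nM

Compound 2 stands within the scatter of compound 1, so neither separates from the other. Compound 3 `O=C(N/N=C/c1ccc(O)cc1)Nc1ccc(Oc2ccnc3[nH]ccc23)c(F)c1` follows from compound 2 through (4-hydroxyphenyl in place of 3,4-dichlorophenyl on a carbon with a double bond to nitrogen), with 4-hydroxyphenyl in place of 3,4-dichlorophenyl on a carbon with a double bond to nitrogen. Going by the values given here, the only measured step at this place is a 1.2-fold higher number from compound 1 to compound 2 (0.08 log units; within the scatter), and it is small. Among the compounds with values here, no measured compound carries 4-hydroxyphenyl, so this is a thin guide, and no change beyond the scatter is expected in this assay. The expected step is a 1.1-fold higher number from compound 2 to compound 3 (0.05 log units; within the scatter). For compound 3 the estimate is 3000 nM, with an expected range of 1200 nM to 8000 nM.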

Compound 3, half-maximal inhibitory concentration: 3760 nM
Estimate against measurement, compound 3: 1.3-fold (0.10 log units) below; the range from low to high includes it.
By their numbers in this assay, from the lowest: compounds 1, 2 and 3 (each within the scatter of the next).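

In this assay, exchanging the halogenated rings for 4-hydroxyphenyl, which brings a hydrogen-bond donor to this carbon, gives a 1.4-fold higher number from compound 2 to compound 3 (0.15 log units; within the scatter) and a 1.7-fold higher number from compound 1 to compound 3 (0.23 log units; within the scatter). This position therefore tolerates the loss of both chlorine atoms and the gain of that donor without any of the three compounds separating from the others. Nothing available explains this result.

As far as these compounds go, whether any group at this place can move the number beyond the scatter remains open. An amine or a carboxylic acid on the ring might answer that.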